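Replacing Ethylamino with Piperazin-1-yl: an Expected Step

The compounds below may be only part of what the source reports. "The series", "measured", "known", "first", "only" and "open" are said of these compounds alone.

Compound 1, `CCNC(=O)CC1CCc2cc(OC)c(OC)cc21`, gives 33.3% in a functional assay on the whole organism (strain Wistar) for inhibition, with Rattus norvegicus as the target, read by paw edema, with stated times of 60 min and 24 h, at a dose of 100 mg/kg by the oral route; on this read-out higher numbers stand for more inhibition at the one dose given (going by the name of the read-out) and lower numbers for less inhibition.
Compound 2, `CCCCCNC(=O)CC1CCc2cc(OC)c(OC)cc21`, gives 46.7% in this assay.
Compound 3, `COc1cc2c(cc1OC)C(CC(=O)NC1CCCC1)CC2`, gives 46.7% in this assay.

Compound 1 stands lowest of the three, with both other numbers higher by steps beyond the scatter: a number 13.4 percentage points higher from compound 1 to compound 2 (beyond the scatter) and a number 13.4 percentage points higher from compound 1 to compound 3 (beyond the scatter). Between the other two there is no change at the digits printed from compound 2 to compound 3 (within the scatter). Compound 4, `COc1cc2c(cc1OC)C(CC(=O)N1CCNCC1)CC2`, differs from compound 1 by piperazin-1-yl in place of ethylamino on a carbonyl carbon. Among the compounds with values here, both measured steps away from compound 1 enlarged the group at the amide, each with a modest rise; the change to compound 4 also enlarges that group, though it brings in a ring with 2 hetero atoms, for which no measured step exists. A modest rise is therefore expected, a number 10.7 percentage points higher from compound 1 to compound 4 (beyond the scatter). Compound 4 is estimated at 44%, between 30% and 58%.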

Compound 4, a percentage reported as inhibition, in the whole organism at one dose (the size of the read-out at that dose, not a potency): 65%
Beside the measured number, compound 4's estimate is 21 percentage points below it; measured number outside the range, above it.
By their numbers in this assay, from the lowest: compound 1; then compounds 2 and 3 (each within the scatter of the next); then compound 4.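

At this carbonyl carbon, piperazin-1-yl stands clear of all three open-chain or carbocyclic amide groups: the step from ethylamino is large (a number 31.7 percentage points higher from compound 1 to compound 4 (beyond the scatter)), and the steps from pentylamino (a number 18.3 percentage points higher from compound 2 to compound 4 (beyond the scatter)) and cyclopentylamino (a number 18.3 percentage points higher from compound 3 to compound 4 (beyond the scatter)) are modest but beyond the scatter. Carrying a ring is therefore not all that counts here, since cyclopentylamino carries one too. Nothing measured here gives a reason for the rise.

Still open, going by these compounds, is what the ring nitrogen contributes. Piperidin-1-yl, morpholin-4-yl or 4-methylpiperazin-1-yl at the same carbonyl carbon would test that.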